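Ethoxy to isopropoxy on the shared core

A few compounds are considered here, and "the series" means these few. Any claim that something is new, unique, unknown or untested is made for them only; others in the source may bear on it.

Measured so far:
Compound 1 `C=CCOc1cccc(/C=N/n2c(-c3ccccc3)nc3ccccc3c2=O)c1`: 300 mg/kg
Compound 2 `CCOc1cccc(/C=N/n2c(-c3ccccc3)nc3ccccc3c2=O)c1`: 100 mg/kg

In a functional assay on the whole organism (strain albino CF-1) with Mus musculus as the target, in the maximal electroshock model, with a stated time of 0.5 h (a lower number here means that less compound is needed, a higher number that more compound is needed for the effect), compound 1 gives 300 mg/kg. Among the compounds with values here, in the same test compound 2 gives 100 mg/kg, which is the lowest of the two numbers so far; the only measured step, a 3.0-fold lower number from compound 1 to compound 2 (0.48 log units; beyond the scatter), is methyl in place of vinyl on a saturated chain carbon bound to an oxygen on an aromatic ring.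

Compound 3 `CC(C)Oc1cccc(/C=N/n2c(-c3ccccc3)nc3ccccc3c2=O)c1` is the next member. The change from compound 2 is methyl in place of hydrogen on a saturated chain carbon bound to an oxygen on an aromatic ring and a saturated chain carbon. Within the data shown here, no measured step covers this kind of change; the step from compound 1 to compound 2 concerns a different part of the chain and only shows that the alkoxy group matters. Among the measured compounds shown here, with no direct precedent, the expectation for this assay is a step of no change at the digits printed from compound 2 to compound 3 (within the scatter), that is, no change beyond the scatter in either direction.

Compound 3 is therefore estimated at 100 mg/kg, with a plausible range from 50 mg/kg to 300 mg/kg.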

Compound 3, minimum effective dose: 300 mg/kg
Estimate against measurement, compound 3: 3.0-fold (0.48 log units) below; the measured number falls inside the stated range.
By their numbers in this assay, from the lowest: compound 2; then compounds 1 and 3 (each within the scatter of the next).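

In this assay, ethoxy to isopropoxy is a change that registers at this position: methyl in place of hydrogen on a saturated chain carbon bound to an oxygen on an aromatic ring and a saturated chain carbon gives a 3.0-fold higher number from compound 2 to compound 3 (0.48 log units; beyond the scatter) in the direction of more compound being needed. Isopropyl in place of allyl on the oxygen gives no change at the digits printed from compound 1 to compound 3 (within the scatter) and so does not separate these two groups, which leaves ethoxy in compound 2 alone with the lowest number among the three compounds. Nothing available bears on the reason for this step.

The compounds shown do not say how methoxy or a longer straight chain such as propoxy or butoxy would compare with ethoxy on this oxygen. They also leave open whether an amine at the end of the chain would fit this series.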